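A few compounds are considered here, and "the series" means these few. Any claim that something is new, unique, unknown or untested is made for them only; others in the source may bear on it.

Compound 1 `Fc1ccc2ncc(-c3nn[nH]n3)cc2c1` in a functional assay on the whole organism (strain Sprague-Dawley) for inhibition, with Rattus norvegicus as the target; a higher number here means that more compound is needed for the effect, a lower number that less compound is needed: < 25 mg/kg, a limit of the assay.
Compound 2 `CCc1cccc2c(=O)c(-c3nn[nH]n3)c[nH]c12` in this assay: 0.312 mg/kg.
Compound 3 `FC(F)(F)c1cccc2cc(-c3nn[nH]n3)cnc12` in this assay: < 25 mg/kg, a limit of the assay.

Among the compounds with values here, compound 2 stands alone: it holds the only measured number in this assay, while the two other entries are limits, as the limit of < 25 mg/kg in this assay, at which 2 of the 3 values shown sit, records. Within the data shown here, no two measured compounds differ in a single place, so no measured step guides the next change.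

Compound 4 `O=c1c(-c2nn[nH]n2)c[nH]c2ccccc12` differs from compound 2 by hydrogen in place of ethyl on an aromatic carbon. With nothing measured to lean on, only a modest loss is expected for this change, a 3.2-fold higher number from compound 2 to compound 4 (0.51 log units; beyond the scatter), not far beyond the scatter. Compound 4 is therefore estimated at 1 mg/kg in this assay, expected to fall between 0.3 mg/kg and 5 mg/kg.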

Compound 4, minimum effective dose: 1.25 mg/kg
The estimate for compound 4 lay 1.3-fold (0.10 log units) below the measured number; the measured number falls inside the stated range.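

Hydrogen in place of ethyl gives the first measured single-place step in the series: in this assay, the change brings a 4.0-fold higher number from compound 2 to compound 4 (0.60 log units; beyond the scatter). Ethyl on this aromatic carbon is therefore not needed for a measurable effect, as compound 4 still gives a measured number without it, but the step lies beyond the scatter and sides with ethyl over hydrogen. No measured property accounts for the size of this step.

Open, as far as these compounds go, is whether a longer chain such as propyl on this same aromatic carbon would lower the number further. Also open, from the compounds shown here alone, is how methoxy or an amine would read at this place.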